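A few compounds are considered here, and "the series" means these few. Any claim that something is new, unique, unknown or untested is made for them only; others in the source may bear on it.

Compound 1 `CCCCCc1ccc(-c2cn(C[C@H](O)[C@H]3OC(=O)C(OCc4ccccc4)=C3OCc3ccccc3)nn2)cc1`: 6220 nM
Compound 2 `O=C1O[C@H]([C@@H](O)Cn2cc(CNS(=O)(=O)c3ccc(Cl)cc3)nn2)C(OCc2ccccc2)=C1OCc1ccccc1`: 2870 nM

In a functional assay on A549 cells (Homo sapiens) for antiproliferative activity, read by MTT assay, with a stated time of 72 h (on this read-out higher numbers stand for weaker inhibition and lower numbers for stronger inhibition), compound 2 has the lower of the two numbers, 2870 nM, so it inhibits more strongly. Compound 3 `O=C1O[C@H]([C@@H](O)Cn2cc(CCO)nn2)C(OCc2ccccc2)=C1OCc1ccccc1` differs from it by hydroxymethyl in place of ((4-chlorophenyl)sulfonyl)amino on a saturated chain carbon bound to an aromatic carbon. Going by the values given here, only one measured step bears on this, the modest 2.2-fold lower number from compound 1 to compound 2 (0.34 log units; beyond the scatter). It is weak guidance, as compound 1 and compound 2 both carry an aromatic ring in the changed group, whereas compound 3 has none there. A moderate rise is therefore expected, and the expected step is a 3.5-fold higher number from compound 2 to compound 3 (0.54 log units; beyond the scatter). For compound 3 the estimated value is 10000 nM, with an expected range of 3000 nM to 40000 nM.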

Compound 3, half-maximal inhibitory concentration: > 100000 nM
Compound 3 ended at the assay's limit; the forecaster's own chance of this, stated with the estimate: 20%; middle value at least 10-fold (1.00 log units) from the limit.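

Compound 3 gives only a limit in this assay, not a number: the limit of > 100000 nM in this assay, at which 1 of the 3 values shown sits. Replacing either group that carries an aromatic ring with a small group that has none costs far more, an at least 34-fold higher number from compound 2 to compound 3 (1.54 log units; beyond the scatter) and an at least 16-fold higher number from compound 1 to compound 3 (1.20 log units; beyond the scatter), than exchanging one ring-bearing group for the other, a 2.2-fold lower number from compound 1 to compound 2 (0.34 log units; beyond the scatter). At this position on the triazole side, the two ring-bearing groups therefore tolerate change much better than 2-hydroxyethyl does. As far as these compounds go, what stays open is whether the aromatic ring itself matters or only the size of the group. A long alkyl chain such as decyl, with no ring, or a plain phenyl would help separate the two.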